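A few compounds are considered here, and "the series" means these few. Any claim that something is new, unique, unknown or untested is made for them only; others in the source may bear on it.

Measured compounds:
compound 1 `O=C(COc1ccc2c(=O)cc(-c3ccccc3)oc2c1)Nc1ccc2ccccc2c1`: > 10000 nM
compound 2 `O=C(COc1c(-c2ccccc2)oc2ccccc2c1=O)Nc1ccc(F)cc1`: > 10000 nM
compound 3 `O=C(COc1ccc2oc(-c3ccccc3)cc(=O)c2c1)Nc1ccc(-c2ccccc2)cc1`: 9710 nM

All three were tested in a functional assay on NCI-H661 cells (Homo sapiens) for antiproliferative activity, read by MTT assay, with a stated time of 72 h; a lower number here means a stronger inhibitor of growth, a higher number a weaker inhibitor of growth. For compound 1 the result > 10000 nM is a limit of the assay rather than a number. For compound 2 the result > 10000 nM is likewise a limit. Compound 3 gives 9710 nM, a measured number. Compound 1 therefore stands at the limit of > 10000 nM in this assay, at which 2 of the 3 values shown sit, and none of the compounds shown is a strong inhibitor of growth.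

Compound 4 `O=C(COc1ccc2c(=O)cc(-c3ccccc3)oc2c1)Nc1ccccc1` has not yet been measured. It differs from compound 1 in one place: phenyl in place of naphthalen-2-yl on an amide-type nitrogen. Going by the values given here, no two measured compounds differ in exactly one place, so there is no measured step of this kind to lean on. What the measured set does show is that every amide substituent tried so far leaves the compounds weak in this assay. Compound 4 is therefore expected to remain weak, with the step that the limit leaves unreadable from compound 1 to compound 4 expected to be none beyond the usual scatter. Compound 4 is estimated at 15000 nM, in a range from 5000 nM to 50000 nM, and the assay may well report only a limit again.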

Compound 4, concentration for 50% growth inhibition: > 10000 nM
Compound 4 ended at the assay's limit; the forecaster's own chance of this, stated with the estimate: 70%; the middle value lies beyond the limit too.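

Compound 1 and compound 4 both give only a limit in this assay, not a number, so no step between them can be read: the limit of > 10000 nM in this assay, at which 3 of the 4 values shown sit.

The compounds shown leave open whether phenyl in place of naphthalen-2-yl changes growth inhibition at all.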